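The source may report more compounds than this note shows. Statements on the series, on what has been measured and on what is new or still open speak of the compounds shown alone.

Compound 1 `COc1ccc(CN(C(=O)CSC(=S)N2CCN(C(=O)OC(C)(C)C)CC2)c2ccc(Br)cc2)cc1` and compound 2 `COc1ccc(CN(C(=O)CSC(=S)N2CCN(C(=O)OC(C)(C)C)CC2)c2ccc(C)cc2)cc1` share one core; compound 3 `COc1cc(N(Cc2ccc(Br)cc2)C(=O)CSC(=S)N2CCN(C(=O)OC(C)(C)C)CC2)cc(OC)c1OC` and compound 4 `COc1cc(N(Cc2ccc(C)cc2)C(=O)CSC(=S)N2CCN(C(=O)OC(C)(C)C)CC2)cc(OC)c1OC` share another, and the difference between the two cores is not broken down here. In a functional assay on HCT-116 cells (Homo sapiens) for inhibition, read by CCK-8 assay, with a stated time of 48 h (on this read-out higher numbers stand for weaker inhibition and lower numbers for stronger inhibition), compound 1 gives only a limit, > 20000 nM. In this assay compound 2 likewise gives only a limit, > 20000 nM. The change methyl in place of bromo on an aromatic carbon thus yields a step that the two limits leave unreadable from compound 1 to compound 2, since both ends sit at the limit of > 20000 nM in this assay, at which 2 of the 3 values shown sit. In this assay, among the compounds with values here, compound 3 gives 11400 nM, the one number in the set. Compound 4 carries the same change, (methyl in place of bromo on an aromatic carbon), on the other core. No readable measured step exists for this change, so only a small step is expected, a 1.2-fold higher number from compound 3 to compound 4 (0.09 log units; within the scatter), resting on compound 3 at 11400 nM. Compound 4 is expected to give 14000 nM in this assay, within 5000 nM to 40000 nM.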

Compound 4, half-maximal inhibitory concentration: > 20000 nM
Compound 4: only a limit was reported; the forecaster's own chance of this, stated with the estimate: 40%; middle value at least 1.4-fold (0.15 log units) from the limit.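

In this assay, methyl in place of bromo on the core of compound 3 gives an at least 1.7-fold higher number from compound 3 to compound 4 (0.24 log units; that floor lies within the scatter). Going by these compounds, compound 4 gives only a limit, > 20000 nM, so the true size of this step stays unknown. The same change on the core of compound 1 cannot be read, so the two cores cannot be compared for this change, and the data offer only a shared ceiling: the limit of > 20000 nM in this assay, at which 3 of the 4 values shown sit.

Open, on these data alone, is whether another group in this place, such as an amine or a carboxylic acid, would give a readable number in this assay on either core. Also open, as far as these compounds go, is whether the change behaves alike on both cores once both ends of each pair give numbers.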